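Working notes: 3-methylthiophen-2-yl in place of 4-fluorophenyl

The source may report more compounds than this note shows. Statements on the series, on what has been measured and on what is new or still open speak of the compounds shown alone.

In a functional assay on MGC-803 cells (Homo sapiens) for antiproliferative activity, read by MTT assay, with a stated time of 72 h (on this read-out lower numbers stand for stronger inhibition and higher numbers for weaker inhibition), compound 1 `O=C(NO)c1ccc(NCc2nc(-c3ccccc3)nn2-c2ccc(Br)cc2)cc1` gives 9300 nM, compound 2 `O=C(NO)c1ccc(NCc2nc(-c3ccccc3)nn2-c2cccc(Cl)c2)cc1` gives 13700 nM and compound 3 `O=C(NO)c1ccc(NCc2nc(-c3ccc(F)cc3)nn2-c2ccccc2)cc1` gives 8960 nM. These three values lie within the scatter of one another, so compound 3 stands level with the other two and not clear of them.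

Compound 4 `Cc1ccsc1-c1nc(CNc2ccc(C(=O)NO)cc2)n(-c2ccccc2)n1` differs from compound 3 in one place: 3-methylthiophen-2-yl in place of 4-fluorophenyl on an aromatic carbon of a five-membered aromatic ring with 3 nitrogen (3-methylthiophen-2-yl in place of 4-fluorophenyl on an aromatic carbon).

Within the data shown here, the one measured step, a 1.5-fold higher number from compound 1 to compound 2 (0.17 log units; within the scatter), lies within the scatter, and it sits on an aromatic nitrogen, not on this carbon. It therefore bears on the change only indirectly, as a sign of how flat the numbers have been so far. Among the measured compounds shown here, no measured pair isolates a change on this carbon, so the direction of the change remains open.

In this assay the expected step is a 1.1-fold higher number from compound 3 to compound 4 (0.05 log units; within the scatter), which is not expected to go beyond the scatter. Compound 4 is estimated at 10000 nM, with an expected range of 4000 nM to 25000 nM.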

Compound 4, half-maximal inhibitory concentration: 8890 nM
The estimate for compound 4 lay 1.1-fold (0.05 log units) above the measured number; low and high end bracket the measured number.
By their numbers in this assay, from the lowest: compounds 4, 3, 1 and 2 (each within the scatter of the next).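

In this assay, among these compounds, the replacement of 4-fluorophenyl by 3-methylthiophen-2-yl gives a 1.0-fold lower number from compound 3 to compound 4 (0.00 log units; within the scatter), the first measured step on this aromatic carbon of the five-membered aromatic ring with 3 nitrogen. The position therefore accepts a one-for-one exchange of a six-membered aromatic ring of carbon only for a five-membered aromatic ring with 1 hetero atom, with the fluorine gone and a methyl group and a sulfur atom present, and the number stays within the scatter. Among the compounds shown here, the flatness earlier seen only on an aromatic nitrogen, in a 1.5-fold higher number from compound 1 to compound 2 (0.17 log units; within the scatter), now has a counterpart on this carbon, although each position rests on a single step, and nothing available explains why the number holds across this exchange.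

Going by these compounds, both groups compared on this carbon are aromatic rings, so it remains open whether a basic amine, a carboxylic acid or a longer alkyl chain would leave the number equally flat. A single pair also cannot show whether the methyl group on the thiophene ring matters, and an unsubstituted thiophen-2-yl group at this carbon would address that.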